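The source may report more compounds than this note shows. Statements on the series, on what has been measured and on what is new or still open speak of the compounds shown alone.

Measured compounds:
- compound 1 `Cc1ccc(N2CCN(C(=O)Nc3ccc(C(C)C)cc3)CC2)nn1`; in an assay on HEK293 cells for inhibition of transient receptor potential cation channel subfamily V member 1 (Homo sapiens), read by FLIPR, at pH 5.5 (on this read-out lower numbers stand for stronger inhibition and higher numbers for weaker inhibition), compound 1 gives only the assay limit > 10000 nM.
- compound 2 `Cc1ccc(N2CCN(C(=O)Nc3ccc(C(F)(F)F)cc3)CC2)nn1`; in this assay compound 2 gives only the assay limit > 10000 nM.
- compound 3 `CC(C)c1ccc(NC(=O)N2CCN(c3nncc4ccccc34)CC2)cc1`; in this assay compound 3 gives only the assay limit > 10000 nM.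

Compound 2 differs from compound 1 by trifluoromethyl in place of isopropyl on an aromatic carbon, and the step that the two limits leave unreadable from compound 1 to compound 2 cannot be read, since both values are limits, as noted in the limit of > 10000 nM in this assay, at which 3 of the 3 values shown sit. The difference between the core of compound 1 and the core of compound 3 is not broken down here. Compound 4 `O=C(Nc1ccc(C(F)(F)F)cc1)N1CCN(c2nncc3ccccc23)CC1` is not yet measured; it differs from compound 3 by trifluoromethyl in place of isopropyl on an aromatic carbon, the same change as that from compound 1 to compound 2. Since compound 3 sits at the limit > 10000 nM and the earlier step is unreadable, the step that the limit leaves unreadable from compound 3 to compound 4 is expected to stay near the limit. Compound 4 is estimated at 20000 nM in this assay, between 5000 nM and 80000 nM.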

Compound 4, half-maximal inhibitory concentration: > 10000 nM
Compound 4: only a limit was reported (the forecaster's own chance of this, stated with the estimate: 85%); the middle value is on the limit's open side.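

No new step can be read between compound 3 and compound 4, as both give only limits: the limit of > 10000 nM in this assay, at which 4 of the 4 values shown sit. The compounds shown leave open whether trifluoromethyl and isopropyl differ in effect on either core.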